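The source may hold more compounds than are shown below. What is called first, only, known or untested is meant among the compounds shown, and "the series" means these compounds.

In a functional assay on SK-N-SH cells (Homo sapiens) for cytotoxicity, read by MTT assay, with a stated time of 24 h (a lower number here means a stronger inhibitor, a higher number a weaker inhibitor), compound 1 `COc1ccc(Cc2cn3cc(Br)ccc3nc2=O)cc1` gives 940 nM while compound 2 `O=c1nc2ccc(Br)cn2cc1Cc1ccccc1` gives 137000 nM as the highest number of the two. Among the measured compounds shown here, the only measured step is a 150-fold higher number from compound 1 to compound 2 (2.16 log units; beyond the scatter) with hydrogen in place of methoxy on an aromatic carbon.

Next in the series is compound 3 `O=c1nc2ccccn2cc1Cc1ccccc1` which differs from compound 2 by hydrogen in place of bromo on an aromatic carbon and in words this is hydrogen in place of bromo on an aromatic carbon of a six-membered aromatic ring with 1 nitrogen, part of a fused or bridged system of two rings.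

For the measured compounds named here, no measured pair tests the bromo directly. The large methoxy step a 150-fold higher number from compound 1 to compound 2 (2.16 log units; beyond the scatter) lies at another place in the molecule and gives neither size nor direction for this change. It argues only for keeping the range wide. The estimated step is a 1.1-fold higher number from compound 2 to compound 3 (0.04 log units; within the scatter) in this assay with no shift beyond the scatter expected. Compound 3 is expected at 150000 nM with an estimated range from 50000 nM to 400000 nM on this thin basis.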

Compound 3, half-maximal inhibitory concentration: 95400 nM
Beside the measured number, compound 3's estimate is 1.6-fold (0.20 log units) above it; low and high end bracket the measured number.
By their numbers in this assay, from the lowest: compound 1; then compounds 3 and 2 (each within the scatter of the next).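

In this assay, among the compounds shown here, hydrogen in place of bromo gives a 1.4-fold lower number from compound 2 to compound 3 (0.16 log units; within the scatter), the first direct reading at this aromatic carbon, two atoms from the ring nitrogen. Where methoxy is absent, the bromo can therefore be exchanged for hydrogen without a shift beyond the scatter, so this pair gives no sign that the bromo matters to the read-out, whereas the methoxy change, a 150-fold higher number from compound 1 to compound 2 (2.16 log units; beyond the scatter), remains the only step here that lies beyond the scatter. No measured information bears on the reason for this result.

Going by these compounds, whether the bromo position stays equally silent with the methoxy in place remains open, since this single pair reads the exchange only where methoxy is absent. On these data alone, it is also open whether a different group on the same carbon, such as chloro, an amine or a carboxylic acid, would move the number beyond the scatter, as the present reading covers only bromo and hydrogen.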